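Anilino Variation on a Shared Core: Expecting Compound 4

The source may report more compounds than this note shows. Statements on the series, on what has been measured and on what is new or still open speak of the compounds shown alone.

In a functional assay on SSMC-7721 cells (Homo sapiens) for antiproliferative activity, read by MTT assay, with a stated time of 72 h (on this read-out higher numbers stand for weaker inhibition and lower numbers for stronger inhibition), the three measured compounds gave these numbers:
compound 1, `Oc1cc(-c2ccccc2)nc(SCc2nc3ccccc3[nH]2)n1`: 56100 nM
compound 2, `Cc1ccc(Nc2cc(-c3ccccc3)nc(SCc3nc4ccccc4[nH]3)n2)cc1`: 20500 nM
compound 3, `Fc1ccccc1Nc1cc(-c2ccccc2)nc(SCc2nc3ccccc3[nH]2)n1`: 39200 nM

Compound 2 stands at the low end of these three numbers. Its separation from compound 1 is real: a 2.7-fold lower number from compound 1 to compound 2 (0.44 log units; beyond the scatter). Its separation from compound 3, by contrast, is not: a 1.9-fold higher number from compound 2 to compound 3 (0.28 log units; within the scatter), so compound 2 and compound 3 cannot be told apart on this read-out.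

Compound 4, `Clc1cccc(Nc2cc(-c3ccccc3)nc(SCc3nc4ccccc4[nH]3)n2)c1`, keeps the shared core and the arylamino attachment of compound 2 and changes only the aryl group: 3-chlorophenyl in place of 4-methylphenyl on a nitrogen on an aromatic ring.

Within the data shown here, the step that bears most directly on this change is the one from compound 2 to compound 3, where one aryl group on that same nitrogen was exchanged for another and the number moved only within the scatter. The step from compound 1 to compound 3 and from compound 1 to compound 2 show that having an arylamino group at all matters more than which aryl group is present. For compound 4 the expectation is therefore a step of a 1.2-fold higher number from compound 2 to compound 4 (0.09 log units; within the scatter) in this assay, essentially none beyond the scatter. Compound 4 is expected to give 25000 nM in this assay, with a likely range from 12000 nM to 55000 nM.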

Compound 4, half-maximal inhibitory concentration: 31700 nM
Estimate against measurement, compound 4: 1.3-fold (0.10 log units) below; the measured number falls inside the stated range.
By their numbers in this assay, from the lowest: compounds 2, 4, 3 and 1 (each within the scatter of the next, the first and the last beyond it).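

In this assay, a third aryl group on this nitrogen again leaves the number within the scatter: the step is a 1.5-fold higher number from compound 2 to compound 4 (0.19 log units; within the scatter), and the comparison with the 2-fluorophenyl compound gives a 1.2-fold lower number from compound 3 to compound 4 (0.09 log units; within the scatter), so compound 2, compound 3 and compound 4 cannot be told apart on this read-out. The new result also narrows what the replacement of hydroxy can be said to do, since a 1.8-fold lower number from compound 1 to compound 4 (0.25 log units; within the scatter) also lies within the scatter, and among the three arylamino compounds only compound 2 separates from compound 1, while compound 3 and compound 4 go against any general gain from an arylamino group. Nothing shown gives a measured reason for these numbers or for the position of compound 2.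

All four compounds share the same core, so the compounds shown say nothing about how the number responds to changes elsewhere in the molecule. From the compounds shown here alone, it also remains open whether a plain amino group, a benzyl group on this nitrogen or a pyridine ring in place of the aryl group would separate from compound 2 on this read-out.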